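Trading a Fluorinated Chain for a Second Aryl Ring

The source may report more compounds than this note shows. Statements on the series, on what has been measured and on what is new or still open speak of the compounds shown alone.

Compound 1, `Fc1cc(C(F)(F)F)ccc1Nc1nc2nonc2nc1Nc1ccc(C(F)(F)F)cc1F`: < 1000 nM, a limit of the assay.
Compound 2, `FC(F)(F)Oc1cccc(Nc2nc3nonc3nc2Nc2cccc(OC(F)(F)F)c2)c1`: 1100 nM.
Compound 3, `Fc1ccccc1Nc1nc2nonc2nc1NCCC(F)(F)F`: > 100000 nM, a limit of the assay.

All three were tested in an assay on mitochondria from L6 cells (Rattus norvegicus) for activation, with a stated time of 90 min; a lower number here means that less compound is needed, a higher number that more compound is needed for the effect. Compound 3 sits at the limit of > 100000 nM in this assay, at which 1 of the 3 values shown sits, so no number is known for it. Compound 1 sits at the limit of < 1000 nM in this assay, at which 1 of the 3 values shown sits. Going by the values given here, compound 2 is the one measured value, and in this assay compound 2 gives 1100 nM.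

The next compound is compound 4, `CCOc1ccccc1Nc1nc2nonc2nc1Nc1ccccc1F`. Its change from compound 3 is 2-ethoxyphenyl in place of 3,3,3-trifluoropropyl on a nitrogen on an aromatic ring. Compound 4 carries an aromatic ring on each of the two nitrogens, as compound 2 does, and compound 2 gives 1100 nM; compound 4 is therefore expected to land near that. The expected step of an at least 50-fold lower number from compound 3 to compound 4 (1.69 log units; beyond the scatter) is a large gain, well beyond the scatter. Compound 4 is estimated at 2000 nM, with a range from 300 nM to 15000 nM.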

Compound 4, half-maximal effective concentration: 5600 nM
The estimate for compound 4 lay 2.8-fold (0.45 log units) below the measured number; low and high end bracket the measured number.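

Putting 2-ethoxyphenyl in place of 3,3,3-trifluoropropyl on this nitrogen is the first single change shown here, and in this assay it gives an at least 17-fold lower number from compound 3 to compound 4 (1.25 log units; beyond the scatter). So, at this position, the aromatic ring with its ethoxy group goes with far less compound being needed than the fluorinated chain. Compound 3 stands at a limit of the assay, so this step is a minimum rather than an exact size: the limit of > 100000 nM in this assay, at which 1 of the 4 values shown sits.

The compounds shown leave open whether the ring itself or its ethoxy group matters more. On these data alone, how a plain phenyl or a piperidine would behave on this nitrogen also remains unknown.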